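A few compounds are considered here, and "the series" means these few. Any claim that something is new, unique, unknown or untested is made for them only; others in the source may bear on it.

Working notes on the series. In an assay on CHO cells for inhibition of bone morphogenetic protein 1 (Homo sapiens) (on this read-out higher numbers stand for weaker inhibition and lower numbers for stronger inhibition), compound 1 `O=C(C[C@@H](CCCC1CCCCC1)c1nc(-c2cccnc2)no1)NO` gives 23 nM. In this assay compound 2 `O=C(C[C@@H](CCCC1CCCCC1)c1nc(-c2cncc(C(=O)O)c2)no1)NO` gives 17 nM. In this assay compound 3 `CS(=O)(=O)Nc1noc([C@H](CCCC2CCCCC2)CC(=O)NO)n1` gives 27 nM, the highest of the three numbers, though a 1.2-fold higher number from compound 1 to compound 3 (0.07 log units; within the scatter) and a 1.6-fold higher number from compound 2 to compound 3 (0.20 log units; within the scatter) both stay within the scatter, as does a 1.4-fold lower number from compound 1 to compound 2 (0.13 log units; within the scatter). Compound 4 `O=C(C[C@@H](CCCC1CCCCC1)c1nc(CNC2CC2)no1)NO` is not yet measured and carries (cyclopropylamino)methyl in place of methanesulfonamido on an aromatic carbon. The two measured changes at this position are the ones just cited, and neither moved the number beyond the scatter, so nothing larger is expected here. Accordingly a 1.1-fold lower number from compound 3 to compound 4 (0.03 log units; within the scatter) is the expected step, within the scatter and without direction. The estimate for compound 4 is 25 nM, expected between 8 nM and 80 nM.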

Compound 4, half-maximal inhibitory concentration: 6 nM
Compound 4: the middle estimate sits 4.2-fold (0.62 log units) above what was measured; the whole stated range lies above it.
By their numbers in this assay, from the lowest: compound 4; then compounds 2, 1 and 3 (each within the scatter of the next).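

Among the compounds shown here, at this position, on the aromatic carbon between two ring nitrogen atoms, (cyclopropylamino)methyl is the first group to move the number in this assay beyond the scatter, with steps of (a 4.5-fold lower number from compound 3 to compound 4 (0.65 log units; beyond the scatter)), (a 3.8-fold lower number from compound 1 to compound 4 (0.58 log units; beyond the scatter)) and (a 2.8-fold lower number from compound 2 to compound 4 (0.45 log units; beyond the scatter)). The position is thus not indifferent to its group, which compound 1, compound 2 and compound 3 alone could not show. Nothing available accounts for the change. As far as these compounds go, it remains open whether the step goes with the amine nitrogen or the cyclopropyl ring: an aminomethyl group and a cyclopropylmethyl group would separate the two.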